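The source may report more compounds than this note shows. Statements on the series, on what has been measured and on what is new or still open speak of the compounds shown alone.

Working notes on the series. Compound 1 `Cc1cc(NC(=O)Cn2cc(-c3ccncc3)nn2)no1` gives 430 nM in a functional assay on BMDM cells (Mus musculus, strain C57BL/6) for inhibition, with a stated time of 2 days; a lower number here means a stronger inhibitor, a higher number a weaker inhibitor. Among the compounds with values here, compound 2 `Cc1cc(NC(=O)Cn2cc(-c3ccc(Cl)cc3)nn2)no1` gives 1910 nM in this assay, the higher of the two numbers so far, with compound 1 as its only neighbour. Within the data shown here, the single measured step, a 4.4-fold higher number from compound 1 to compound 2 (0.65 log units; beyond the scatter), shows that exchanging the aromatic group on this aromatic carbon moves the number modestly but beyond the scatter. Compound 3 `Cc1cc(NC(=O)Cn2cc(-c3cccs3)nn2)no1` differs from compound 2 as follows: thiophen-2-yl in place of 4-chlorophenyl on an aromatic carbon. Among the measured compounds shown here, no measured step involves a thiophen-2-yl entering, so the size of this step can only be judged by analogy with the one aryl exchange seen, and a shift of similar or smaller size is expected, leaning toward a lower number because compound 1 with pyridin-4-yl gives 430 nM. The expected step is a 1.9-fold lower number from compound 2 to compound 3 (0.28 log units; within the scatter). Compound 3 is estimated at 1000 nM, with a range from 350 nM to 3000 nM.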

Compound 3, half-maximal inhibitory concentration: > 30000 nM
Compound 3 gave a limit, no number (the forecaster's own chance of this, stated with the estimate: 5%); at least 30-fold (1.47 log units) between middle value and limit.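

In this assay compound 3 gives a limit of the assay, not a number: the limit of > 30000 nM in this assay, at which 1 of the 3 values shown sits.

Thiophen-2-yl in place of 4-chlorophenyl gives an at least 15-fold higher number from compound 2 to compound 3 (1.19 log units; beyond the scatter), and thiophen-2-yl in place of pyridin-4-yl gives an at least 69-fold higher number from compound 1 to compound 3 (1.84 log units; beyond the scatter); both are far larger than the one earlier aryl exchange, a 4.4-fold higher number from compound 1 to compound 2 (0.65 log units; beyond the scatter). This aromatic carbon of the five-membered aromatic ring with 3 nitrogen therefore does not accept every aromatic group equally: among these three compounds, the two six-membered aromatic rings give measurable numbers, while the five-membered aromatic ring with 1 hetero atom gives only a limit.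

The compounds shown leave open whether this loss follows from ring size or from the sulfur atom and its attachment. A furan-2-yl, a thiophen-3-yl or a benzyl group at this carbon would separate these readings.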